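The source may hold more compounds than are shown below. What is called first, only, known or untested is meant among the compounds shown, and "the series" means these compounds.

In an ADME assay on HepG2 2.2.15 cells (Homo sapiens) for cytotoxicity (a lower number here means that less compound is tolerated, a higher number that more compound is tolerated), three compounds sharing one core have been measured so far: compound 1 (`O=c1c(CCO)c(-c2ccccc2Cl)c2cc(Cl)ccc2n1-c1ccccc1`) gives 26000 nM, compound 2 (`CCC(=O)OCCc1c(-c2ccccc2Cl)c2cc(Cl)ccc2[nH]c1=O`) gives 95000 nM, and compound 3 (`CCCCCCCC(=O)OCCc1c(-c2ccccc2Cl)c2cc(Cl)ccc2[nH]c1=O`) gives 78000 nM. Compound 3 thus lies within the scatter of compound 2 and beyond the scatter above compound 1. Compound 4 (`CC(=O)NCC(=O)OCCc1c(-c2ccccc2Cl)c2cc(Cl)ccc2[nH]c1=O`) differs from compound 3 in one place: acetamido in place of hexyl on a saturated chain carbon bound to a carbonyl carbon. Going by the values given here, the one measured step that bears on this change lies in the same chain: a 1.2-fold lower number from compound 2 to compound 3 (0.09 log units; within the scatter). It swaps pentyl for hydrogen, and the number stays within the scatter. Among the compounds with values here, that step adds carbon only, and no measured compound carries the acetamido group, so the evidence is indirect. No step beyond the scatter is therefore expected in this assay, and the expected step is a 1.1-fold higher number from compound 3 to compound 4 (0.04 log units; within the scatter). Compound 4 is estimated at 85000 nM, with an expected range of 40000 nM to 180000 nM.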

Compound 4, half-maximal cytotoxic concentration: 110000 nM
For compound 4 the middle estimate is 1.3-fold (0.11 log units) below the measured one, and the stated range covers the measured number.
By their numbers in this assay, from the lowest: compound 1; then compounds 3, 2 and 4 (each within the scatter of the next).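

In this assay, the saturated chain carbon bound to a carbonyl carbon now carries a group containing nitrogen and oxygen, whereas the earlier esters of compound 2 and compound 3 carried only carbon chains there. Neither new comparison lies beyond the scatter: acetamido in place of hexyl gives (a 1.4-fold higher number from compound 3 to compound 4 (0.15 log units; within the scatter)), and acetamido in place of methyl gives (a 1.2-fold higher number from compound 2 to compound 4 (0.06 log units; within the scatter)), so at this place the number shows no measurable response to acetamido, with its hydrogen-bond donor and acceptor, against either alkyl group. Nothing presented here accounts for this result.

Going by these compounds, whether a free amine, a carboxylic acid or a phenyl ring at this place would also stay within the scatter remains open. Also open, on these data alone, is whether acetamido would behave the same way on a longer chain.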